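A Chloro Step from Phenyl to 4-Chlorophenyl

This account rests on a few compounds, and the source may have more. Where it says the series, first, only, none or still open, it means among the compounds named here.

In a functional assay on MCF7 cells (Homo sapiens) for inhibition, read by sulforhodamine B assay, with a stated time of 48 h (on this read-out higher numbers stand for weaker inhibition of growth and lower numbers for stronger inhibition of growth), compound 3 `Cc1ccc(-c2c(CNC(C)(C)C)c(C(=O)O)nn2-c2ccccc2)cc1` shows only the limit > 688000 nM and no number. Compound 2 `CC(C)(C)NCc1c(C(=O)O)nn(-c2ccccc2)c1-c1ccc(Cl)cc1` likewise shows only the limit > 652000 nM and no number. Compound 1 `CCOC(=O)c1nn(-c2ccccc2)c(-c2ccc(C)cc2)c1CNC(C)(C)C` gives 78200 nM; > 585000 nM (2 entries) across its entries.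

Compound 4 `Cc1ccc(-c2c(CNC(C)(C)C)c(C(=O)O)nn2-c2ccc(Cl)cc2)cc1` differs from compound 3 by one change chloro in place of hydrogen on an aromatic carbon that turns phenyl to 4-chlorophenyl, para to a large group. Within the data shown here, the only measured step that the two limits leave unreadable from compound 2 to compound 3 also involves chloro on an aromatic carbon, but its size cannot be read. With no readable size to go on, the expected change is an at least 1.1-fold lower number from compound 3 to compound 4 (0.05 log units; that floor lies within the scatter) and none beyond the scatter. Compound 4 is estimated at 600000 nM within 150000 nM to 800000 nM and may again report only a limit.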

Compound 4, concentration for 50% growth inhibition: > 629000 nM
Compound 4: a limit, no number (the forecaster's own chance of this, stated with the estimate: 75%); at least 1.0-fold (0.02 log units) between middle value and limit.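

Compound 3 and compound 4 each show only a limit, not a number, so no size can be read for the step between them. As far as these compounds go, whether chloro in place of hydrogen changes growth inhibition at all remains open.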